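Swapping a nitrile for a carboxylic acid on a sulfonyl hydrazide

The compounds below may be only part of what the source reports. "The series", "measured", "known", "first", "only" and "open" are said of these compounds alone.

Measured compounds:
compound 1, `CC(=O)Nc1ccc(S(=O)(=O)NNc2ccc(Cl)cc2)cc1`, 155 nM
compound 2, `N#Cc1ccc(S(=O)(=O)NNc2ccc(Br)cc2)cc1`, 176 nM

Both compounds were tested in an assay for inhibition of Indoleamine 2,3-dioxygenase 1 (Homo sapiens), read by spectrophotometry, with stated times of 1 h and 4 h; on this read-out higher numbers stand for weaker inhibition and lower numbers for stronger inhibition. Compound 1 gives 155 nM and compound 2 gives 176 nM. Compound 2 has the highest of the two numbers, but its gap to compound 1 is within the scatter, so the two cannot be told apart on these data.

Compound 3, `O=C(O)c1ccc(S(=O)(=O)NNc2ccc(Br)cc2)cc1`, has not yet been measured. It differs from compound 2 in one place: carboxy in place of cyano on an aromatic carbon. Within the data shown here, no step between measured compounds shows what such a change does, so the expectation rests on compound 2 alone. Without a comparable step there is no ground to foresee a large shift; a move within the scatter, or a little beyond it toward weaker inhibition, seems most likely, and the uncertainty is wide. Compound 3 is therefore estimated at 300 nM, with a range of 100 nM to 1200 nM, which is expected to mean a step of a 1.7-fold higher number from compound 2 to compound 3 (0.23 log units; within the scatter).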

Compound 3, half-maximal inhibitory concentration: 61 nM
Compound 3: middle estimate off by 4.9-fold (0.69 log units), on the high side; measured number outside the range, below it.
By their numbers in this assay, from the lowest: compound 3; then compounds 1 and 2 (each within the scatter of the next).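

In this assay, carboxy in place of cyano on an aromatic carbon, para to a large group, gives a 2.9-fold lower number from compound 2 to compound 3 (0.46 log units; beyond the scatter); the step is modest, but it lies beyond the scatter. Among these compounds, this is the first single-place change. The two earlier compounds differ from each other in more than one place and could not show how this position responds to a change on its own. It shows that the position does respond, and that a carboxy group, which carries a hydrogen-bond donor where cyano has none, is accepted here without any loss in this measurement.

Nothing in the available data bears on why the number falls. On these data alone, a methyl ester or a primary amide on the same aromatic carbon would help show whether the gain belongs to the carboxy group itself or extends to close relatives, and it also remains open whether the same swap would give a similar step with chlorine in place of the bromine on the other ring.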